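Methyl for hydroxyl hydrogen across two dienone cores

A few compounds are considered here, and "the series" means these few. Any claim that something is new, unique, unknown or untested is made for them only; others in the source may bear on it.

Measured compounds:
compound 1 `COc1cccc(/C=C/C(=O)C(=Cc2cc(OC)c(OC)c(OC)c2)C(=O)/C=C/c2cccc(OC)c2OC)c1OC` — 230 nM
compound 2 `COc1cc(C=C(C(=O)/C=C/c2cccc(OC)c2OC)C(=O)/C=C/c2cccc(OC)c2OC)cc(OC)c1O` — 240 nM
compound 3 `COc1ccc(OC)c(/C=C/C(=O)C(=Cc2ccc(O)c(OC)c2)C(=O)/C=C/c2cc(OC)ccc2OC)c1` — 190 nM

All three numbers come from a functional assay on A549 cells (Homo sapiens) for antiproliferative activity, read by sulforhodamine B assay, with a stated time of 48 h; on this read-out lower numbers stand for stronger inhibition and higher numbers for weaker inhibition. Compound 1 and compound 2 share a core and differ in one place, (methyl in place of hydrogen on an oxygen on an aromatic ring). The resulting step is a 1.0-fold lower number from compound 2 to compound 1 (0.02 log units; within the scatter), so the methyl brought no shift that the assay can resolve. Compound 3 stands on a different core; how that core differs from the core of compound 2 is not broken down here. Its number and those of compound 1 and compound 2 all lie within the usual scatter of one another, so no order among the three can be read off.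

Compound 4 `COc1ccc(OC)c(/C=C/C(=O)C(=Cc2ccc(OC)c(OC)c2)C(=O)/C=C/c2cc(OC)ccc2OC)c1` has not yet been measured in this assay. It differs from compound 3 by methyl in place of hydrogen on an oxygen on an aromatic ring. The place of the change is described in the same words as for the change from compound 2 to compound 1, so this is the same change, here made on the core of compound 3. Among the compounds with values here, the only guide is that earlier pair, where a 1.0-fold lower number from compound 2 to compound 1 (0.02 log units; within the scatter) was seen. On that basis the step from compound 3 to compound 4 is expected to be no change at the digits printed from compound 3 to compound 4 (within the scatter), resting on the flat step a 1.0-fold lower number from compound 2 to compound 1 (0.02 log units; within the scatter). The starting point is the value of compound 3, 190 nM. Compound 4 is therefore estimated at 190 nM in this assay. The expected range for compound 4 runs from 95 nM to 400 nM, wide enough to cover the chance that the change behaves differently on this core.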

Compound 4, half-maximal inhibitory concentration: 400 nM
For compound 4 the middle estimate is 2.1-fold (0.32 log units) below the measured one; the range from low to high includes it.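

In this assay, going from hydroxy to methoxy, which turns the 4-hydroxy-3-methoxyphenyl group into 3,4-dimethoxyphenyl, gives a 2.1-fold higher number from compound 3 to compound 4 (0.32 log units; beyond the scatter). Set beside the same change on the other core, the new step cannot be told apart from the earlier flat one: the same change on two cores in this assay, a 1.0-fold lower number (0.02 log units; within the scatter) from compound 2 to compound 1 and a 2.1-fold higher number (0.32 log units; beyond the scatter) from compound 3 to compound 4, 2.2-fold (0.34 log units) apart, within the scatter of two such steps This shows that the two results are compatible with one effect of the change on both cores, but it does not establish that the effect is the same, nor that it depends on the core, since one pair per core gives too little to separate a small real shift from scatter, and no cause can be assigned to either step.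

The compounds shown leave open whether the higher number on the core of compound 3 would recur on further cores in this series, and whether it would hold in a repeat measurement of the pair. They also leave open what other groups would do at the same oxygen-bearing place on the aromatic ring, such as an ethoxy group or a longer ether chain, or an amine or a carboxylic acid in place of the hydroxy.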